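A few compounds are considered here, and "the series" means these few. Any claim that something is new, unique, unknown or untested is made for them only; others in the source may bear on it.

In a functional assay on MDA-MB-468 cells (Homo sapiens) for antiproliferative activity (on this read-out lower numbers stand for stronger inhibition of growth and higher numbers for weaker inhibition of growth), compound 1 `COc1ccc(-c2nc3cc(F)ccc3s2)cc1C` gives 58 nM. Compound 2 `COc1ccc(-c2nc3cc(F)ccc3s2)cc1OC` gives < 0.1 nM, which is a limit of the assay and not a number. Compound 3 `COCOc1ccc(-c2nc3cc(F)ccc3s2)cc1OC` differs from compound 2 by methoxy in place of hydrogen on a saturated chain carbon bound to an oxygen on an aromatic ring, which turns a methoxy into a methoxymethoxy. For the measured compounds named here, the only measured step, an at least 580-fold lower number from compound 1 to compound 2 (2.76 log units; beyond the scatter), has methoxy in place of methyl on an aromatic carbon, at a different place, and shows that one small exchange can shift the number greatly. A smaller shift towards weaker inhibition is therefore expected in this assay, and the expected step is an at least 30-fold higher number from compound 2 to compound 3 (1.47 log units; beyond the scatter). Compound 3 is estimated at 3 nM, with an expected range of 0.1 nM to 60 nM.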

Compound 3, concentration for 50% growth inhibition: 48 nM
The estimate for compound 3 lay 16-fold (1.20 log units) below the measured number, and the stated range covers the measured number.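

The methoxy group that compound 2 carries is not a place where the chain can simply grow: turning it into a methoxymethoxy gives an at least 480-fold higher number from compound 2 to compound 3 (2.68 log units; beyond the scatter) in this assay. For the compounds shown here, the earlier step concerned a different place, so this is the first sign that a change at this saturated chain carbon also matters greatly. Compound 2 stands at a limit of the assay and not at a number, so this step has only a lower bound: the limit of < 0.1 nM in this assay, at which 1 of the 3 values shown sits.

The compounds shown leave open how far the number moves with a smaller addition at this carbon, such as a methyl, which would give an ethoxy. They also leave open how an amine or a carboxylic acid there would read.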